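Benzyl in Place of Methoxyphenyl on the Sulfonyl Sulfur

The source may report more compounds than this note shows. Statements on the series, on what has been measured and on what is new or still open speak of the compounds shown alone.

Compound 2 `COc1ccc(-c2cc(=O)c3c(OC)cc(OC)cc3n2S(=O)(=O)c2ccc(OC)cc2)cc1` reports only a limit in a functional assay on HepG2 cells (Homo sapiens) for antiproliferative activity, with a stated time of 72 h (on this read-out lower numbers stand for an effect already at smaller amounts and higher numbers for an effect only at larger amounts of compound), namely > 82700 nM. Compound 1 `COc1ccc(-c2cc(=O)c3c(OC)cc(OC)cc3n2S(=O)(=O)c2ccc(Br)cc2)cc1` gives 16300 nM in this assay. Among the compounds with values here, the single measured step, an at least 5.0-fold higher number from compound 1 to compound 2 (0.70 log units; beyond the scatter), is the only one that bears on the change at hand, and it ends at the limit (the limit of > 82700 nM in this assay, at which 1 of the 2 values shown sits). Compound 3 `COc1ccc(-c2cc(=O)c3c(OC)cc(OC)cc3n2S(=O)(=O)Cc2ccccc2)cc1` carries the change (benzyl in place of 4-methoxyphenyl on a sulfonyl sulfur), which again removes the methoxy from the ring on the sulfonyl sulfur. The step is expected to be an at least 2.0-fold lower number from compound 2 to compound 3 (0.31 log units; beyond the scatter). Compound 3 is therefore estimated at 40000 nM, with a range from 10000 nM to 120000 nM.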

Compound 3, half-maximal effective concentration: > 34400 nM
Compound 3: a limit, no number; the forecaster's own chance of this, stated with the estimate: 40%; the middle value is on the limit's open side.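

Moving from an aromatic ring directly on the sulfonyl sulfur to benzyl does not restore a measurable effect in this assay, and the change reads as an at least 2.1-fold higher number from compound 1 to compound 3 (0.32 log units; beyond the scatter). Within the compounds shown, only the 4-bromophenyl of compound 1 gives a number, while the 4-methoxyphenyl and benzyl replacements both end at limits. Compound 3 reports only a limit, and compound 2 does too, so the step between them cannot be read: the limit of > 34400 nM in this assay, at which 1 of the 3 values shown sits.

On these data alone, whether benzyl and 4-methoxyphenyl differ at all remains open. So does how a 4-aminophenyl or a longer chain such as phenylethyl on the sulfonyl sulfur would compare with compound 1.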